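Heptyl to 4-fluorophenyl step from compound 1

The compounds below may be only part of what the source reports. "The series", "measured", "known", "first", "only" and "open" are said of these compounds alone.

Measured in an ADME assay on PANC-1 cells (Homo sapiens) for cytotoxicity, read by sulforhodamine B assay, with a stated time of 48 h, tested at 10 uM; a higher number here means more inhibition at the concentration tested (going by the name of the read-out), a lower number less inhibition:
compound 1 `CCCCCCCc1cn(C(c2ccccc2)c2cc3cc(Br)ccc3nc2OC)nn1` gives 16.6%
compound 2 `COc1nc2ccc(Br)cc2cc1C(c1ccccc1)n1cc(CCCCCO)nn1` gives 19.6%
compound 3 `CCCCCCc1cn(C(c2ccccc2)c2cc3cc(Br)ccc3nc2OC)nn1` gives 6.08%

Compound 1 stands second highest of the three numbers; the nearest is a number 3 percentage points higher from compound 1 to compound 2 (within the scatter), within the scatter, and the furthest is a number 10.5 percentage points lower from compound 1 to compound 3 (beyond the scatter), beyond it. Compound 4 `COc1nc2ccc(Br)cc2cc1C(c1ccccc1)n1cc(-c2ccc(F)cc2)nn1` differs from compound 1 by 4-fluorophenyl in place of heptyl on an aromatic carbon. Among the compounds with values here, no measured step exchanges an alkyl chain for an aromatic ring. The steps seen only shorten the chain (a number 10.5 percentage points lower from compound 1 to compound 3 (beyond the scatter)) or put a hydroxy on it (a number 3 percentage points higher from compound 1 to compound 2 (within the scatter)), and only the shortening moves beyond the scatter. The change to compound 4 is larger than either, and its direction cannot be read from these three compounds. The expected step is a number 0.6 percentage points lower from compound 1 to compound 4 (within the scatter), not beyond the scatter, with a wide range. Compound 4 is estimated at 16%, between 3% and 33%.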

Compound 4, a percentage reported as inhibition, at one concentration (the size of the read-out at that concentration, not a potency): 14.9%
Beside the measured number, compound 4's estimate is 1.1 percentage points above it, and the stated range covers the measured number.
By their numbers in this assay, from the lowest: compounds 3, 4, 1 and 2 (each within the scatter of the next, the first and the last beyond it).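

In this assay, this aromatic carbon of the five-membered ring carries an aromatic ring as well as an alkyl chain with no step beyond the scatter: 4-fluorophenyl stands in place of heptyl (a number 1.7 percentage points lower from compound 1 to compound 4 (within the scatter)), hexyl (a number 8.8 percentage points higher from compound 3 to compound 4 (within the scatter)) and 5-hydroxypentyl (a number 4.7 percentage points lower from compound 2 to compound 4 (within the scatter)). Compound 4 thus lies within the scatter of all three chain compounds, even though compound 3 and compound 1 differ beyond it. Nothing available explains this closeness. Still open, from the compounds shown here alone, is what phenyl without the fluorine, an amine or a carboxylic acid would give at this position.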